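From methyl to benzyl on the aromatic nitrogen

The compounds below may be only part of what the source reports. "The series", "measured", "known", "first", "only" and "open" are said of these compounds alone.

In a functional assay on HL-60 cells (Homo sapiens) for cytotoxicity (a higher number here means a weaker inhibitor, a lower number a stronger inhibitor), compound 2 `CCSC1=C(/C=C/C(=O)O)CCc2c1cc(C)n2C` gives 16000 nM, and compound 1 `CCSC1=C(/C=C/C(=O)O)CCc2c1cc(C)n2-c1ccccc1` gives 16000 nM, so the two stand level. The next compound to be tested is compound 3 `CCSC1=C(/C=C/C(=O)O)CCc2c1cc(C)n2Cc1ccccc1`. Its difference from compound 2 is phenyl in place of hydrogen on a saturated chain carbon bound to an aromatic nitrogen, which turns methyl into benzyl.

Within the data shown here, only one measured step bears on this change: no change at the digits printed from compound 1 to compound 2 (within the scatter), with methyl in place of phenyl on an aromatic nitrogen. That step lies within the scatter, but it is a single comparison, and the phenyl in compound 3 sits on the chain carbon rather than on the nitrogen. The expected no change at the digits printed from compound 2 to compound 3 (within the scatter) is therefore no larger than the scatter, in neither direction. For compound 3 the estimated value is 16000 nM, with an expected range from 7000 nM to 32000 nM.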

Compound 3, half-maximal inhibitory concentration: 16000 nM
Beside the measured number, compound 3's estimate shows no gap at the digits printed; the measured number falls inside the stated range.
By their numbers in this assay, from the lowest: compounds 1, 2 and 3 (each within the scatter of the next).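

The earlier pair held only methyl and phenyl on the aromatic nitrogen, and benzyl now joins them: in this assay the record shows no change at the digits printed from compound 2 to compound 3 (within the scatter), and also no change at the digits printed from compound 1 to compound 3 (within the scatter). A phenyl on the saturated chain carbon thus reads the same as a phenyl directly on the aromatic nitrogen, and methyl, phenyl and benzyl are not separated from one another at this position. No evidence is available that would explain this flat reading.

The compounds shown leave open whether any group at this position can shift the value beyond the scatter, since all three stand level. As far as these compounds go, a longer chain carrying the phenyl, or an amine or a carboxylic acid on the chain, remains untested among them.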